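Hydroxymethyl to methyl: what to expect of compound 4

This account rests on a few compounds, and the source may have more. Where it says the series, first, only, none or still open, it means among the compounds named here.

Of the compounds shown here, three sharing one core have been measured in an ADME assay on HeLa cells (Homo sapiens) for cytotoxicity, with a stated time of 72 h (a lower number here means that less compound is tolerated, a higher number that more compound is tolerated), so far. They are compound 1 (`COc1ccc(/C=C\c2cc(OC)c(OC)c(OC)c2)cc1NC(=O)[C@H](CO)NC(=O)[C@H](CCCNC(=N)N)NC(=O)[C@H](CCCCN)NC(=O)c1ccccc1`), compound 2 (`COc1ccc(/C=C\c2cc(OC)c(OC)c(OC)c2)cc1NC(=O)[C@H](C)NC(=O)[C@H](CCCNC(=N)N)NC(=O)[C@H](CCCCN)NC(=O)c1ccccc1`) and compound 3 (`COc1ccc(/C=C\c2cc(OC)c(OC)c(OC)c2)cc1NC(=O)[C@H](CO)NC(=O)[C@H](CCCNC(=N)N)NC(=O)[C@H](CCCNC(=N)N)NC(=O)c1ccccc1`). The numbers read 61.8 nM for compound 1, 24.6 nM for compound 2 and 29.2 nM for compound 3. Compound 3 thus stands within the scatter of compound 2 and beyond the scatter under compound 1.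

Compound 4 (`COc1ccc(/C=C\c2cc(OC)c(OC)c(OC)c2)cc1NC(=O)[C@H](C)NC(=O)[C@H](CCCNC(=N)N)NC(=O)[C@H](CCCNC(=N)N)NC(=O)c1ccccc1`) is not yet measured. It differs from compound 3 by a single change (hydrogen in place of hydroxy on a saturated chain carbon, two bonds along the chain from an amide-type nitrogen and a carbonyl carbon), which is hydrogen in place of hydroxy on a saturated chain carbon, two bonds along the chain from an amide-type nitrogen and a carbonyl carbon, or hydroxymethyl to methyl.

The same change has been seen once, as a 2.5-fold lower number from compound 1 to compound 2 (0.40 log units; beyond the scatter) in a modest move. Going by the values given here, the other measured step, a 2.1-fold lower number from compound 1 to compound 3 (0.33 log units; beyond the scatter) and also modest, is the one that compound 4 inherits through compound 3. Whether the two steps add up cannot be told from three compounds, so a similar modest drop is expected, with a wide margin. The expected step is a 2.2-fold lower number from compound 3 to compound 4 (0.35 log units; beyond the scatter) on this reasoning. Compound 4 is estimated at 13 nM and is expected to fall from 6.5 nM up to 27 nM in most measurements.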

Compound 4, half-maximal cytotoxic concentration: 65.7 nM
Beside the measured number, compound 4's estimate is 5.1-fold (0.70 log units) below it; measured number above the stated range.
By their numbers in this assay, from the lowest: compounds 2 and 3 (each within the scatter of the next); then compounds 1 and 4 (each within the scatter of the next).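

In this assay, the change from hydroxymethyl to methyl now gives a 2.3-fold higher number from compound 3 to compound 4 (0.35 log units; beyond the scatter), so its direction at this position is not fixed but depends on what the other chain carries: the same change on two cores in this assay, a 2.5-fold lower number (0.40 log units; beyond the scatter) from compound 1 to compound 2 and a 2.3-fold higher number (0.35 log units; beyond the scatter) from compound 3 to compound 4, 5.7-fold (0.75 log units) apart, beyond the scatter of two such steps

The exchange on that other chain turns over in the same way, since with methyl in place of hydroxymethyl the group of 4 heavy atoms in place of the group of 2 heavy atoms gives a 2.7-fold higher number from compound 2 to compound 4 (0.43 log units; beyond the scatter): the same change on two cores in this assay, a 2.1-fold lower number (0.33 log units; beyond the scatter) from compound 1 to compound 3 and a 2.7-fold higher number (0.43 log units; beyond the scatter) from compound 2 to compound 4, 5.7-fold (0.75 log units) apart, beyond the scatter of two such steps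

Across these four compounds the two changes therefore do not act independently, as each lowers the number when made alone on compound 1 and raises it when made on the compound that already carries the other.

The compounds shown leave open whether this reversal is tied to hydroxymethyl and methyl in particular, or would also appear with an amine, a carboxylic acid or a longer chain on the same saturated chain carbon. They also give no means of telling why the two changes depend on each other, and a single set of four compounds cannot show whether the same dependence holds on any other core.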